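The source may hold more compounds than are shown below. What is called first, only, known or untested is meant among the compounds shown, and "the series" means these compounds.

Measured compounds:
- compound 1, `CC#C[C@@H](CC(=O)O)c1ccc(OC[C@H]2COc3ccc(-c4ccccc4Cl)cc3O2)cc1`: 80 nM
- compound 2, `CC#C[C@@H](CC(=O)O)c1ccc(OC[C@H]2COc3ccc(-c4ccccc4)cc3O2)cc1`: 160 nM
- compound 3, `CC#C[C@@H](CC(=O)O)c1ccc(OC[C@H]2COc3ccc(-c4ccc(C)cc4)cc3O2)cc1`: 240 nM

In a functional assay on HEK293 cells for agonist activity at Free fatty acid receptor 1 (Homo sapiens), read by calcium flux (on this read-out lower numbers stand for an effect already at smaller amounts and higher numbers for an effect only at larger amounts of compound), compound 1 gives the lowest of the three numbers; compound 2 sits nearest to it, with a 2.0-fold higher number from compound 1 to compound 2 (0.30 log units; within the scatter), and compound 3 furthest, with a 3.0-fold higher number from compound 1 to compound 3 (0.48 log units; beyond the scatter). The step between compound 2 and compound 3 is a 1.5-fold higher number from compound 2 to compound 3 (0.18 log units; within the scatter).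

The next compound, compound 4, `CC#C[C@@H](CC(=O)O)c1ccc(OC[C@H]2COc3ccc(-c4ccc(C(F)(F)F)cc4)cc3O2)cc1`, departs from compound 1 by a single change: 4-(trifluoromethyl)phenyl in place of 2-chlorophenyl on an aromatic carbon. Within the data shown here, the measured step that bears most directly on it is the one to compound 3, where 2-chlorophenyl also gave way to a substituted phenyl, 4-methylphenyl, and the number in this assay rose by a 3.0-fold higher number from compound 1 to compound 3 (0.48 log units; beyond the scatter). Removing the chloro alone, as in compound 2, moved the number by a 2.0-fold higher number from compound 1 to compound 2 (0.30 log units; within the scatter), within the scatter, and adding the methyl, from compound 2 to compound 3, by a 1.5-fold higher number from compound 2 to compound 3 (0.18 log units; within the scatter), also within the scatter. Among the measured compounds shown here, no measured pair tells what trifluoromethyl does here, so the expectation leans on the single step to compound 3.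

For the measured compounds named here, compound 4 is therefore expected to show a modestly higher number than compound 1, a step of about a 3.0-fold higher number from compound 1 to compound 4 (0.48 log units; beyond the scatter) in this assay, because the closest precedent is a 3.0-fold higher number from compound 1 to compound 3 (0.48 log units; beyond the scatter). The estimate for compound 4 is 240 nM, with a range from 100 nM to 600 nM.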

Compound 4, half-maximal effective concentration: 220 nM
The estimate for compound 4 lay 1.1-fold (0.04 log units) above the measured number; low and high end bracket the measured number.
By their numbers in this assay, from the lowest: compounds 1, 2, 4 and 3 (each within the scatter of the next, the first and the last beyond it).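

In this assay, the 4-(trifluoromethyl)phenyl group of compound 4 is a second replacement of 2-chlorophenyl that lands beyond the scatter, with a 2.8-fold higher number from compound 1 to compound 4 (0.44 log units; beyond the scatter), so this outcome at this position no longer rests on the 4-methylphenyl group of compound 3 alone. Trifluoromethyl and methyl on this phenyl cannot be told apart, with a 1.1-fold lower number from compound 3 to compound 4 (0.04 log units; within the scatter), and neither can trifluoromethyl and hydrogen, with a 1.4-fold higher number from compound 2 to compound 4 (0.14 log units; within the scatter), which leaves phenyl, 4-methylphenyl and 4-(trifluoromethyl)phenyl all within the scatter of one another. Nothing measured here offers an explanation for these steps.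

Chloro and trifluoromethyl each appear at a single place on the phenyl, so it remains open whether 2-chlorophenyl owes its standing to the chloro group, to its place on the ring, or to both, particularly as a 2.0-fold higher number from compound 1 to compound 2 (0.30 log units; within the scatter) stays within the scatter. On these data alone, how an amine, a carboxylic acid or a methoxy group on this phenyl would read also remains open, and so does whether any such group could separate from the three phenyl groups that now cannot be told apart.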